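A few compounds are considered here, and "the series" means these few. Any claim that something is new, unique, unknown or untested is made for them only; others in the source may bear on it.

Compound 2 `Fc1ccccc1-c1cc(COc2ccccc2-c2nc3ccccc3s2)on1` carries the highest of the two numbers shown so far, though the gap to its only neighbour is within the scatter: in a functional assay on COLO 205 cells (Homo sapiens) for cytotoxicity, read by MTT assay, with a stated time of 24 h (on this read-out lower numbers stand for stronger inhibition and higher numbers for weaker inhibition), compound 2 gives 18300 nM. Compound 1 `Brc1ccc(-c2cc(COc3ccccc3-c3nc4ccccc4s3)on2)cc1` is that neighbour, and in this assay compound 1 gives 16400 nM. Going by the values given here, the single measured step, a 1.1-fold higher number from compound 1 to compound 2 (0.05 log units; within the scatter), stays within the scatter. Compound 3 `Clc1ccc(-c2cc(COc3ccccc3-c3nc4ccccc4s3)on2)cc1` is not yet measured; it differs from compound 2 by 4-chlorophenyl in place of 2-fluorophenyl on an aromatic carbon. Among the compounds with values here, the one measured step bears on this directly, since it too exchanged one halogen-bearing phenyl for another at the same place without moving the number, and compound 3 carries 4-chlorophenyl where compound 1 carries 4-bromophenyl. No step beyond the scatter is therefore expected, and the change from compound 2 to compound 3 is estimated as a 1.1-fold lower number from compound 2 to compound 3 (0.04 log units; within the scatter). In this assay compound 3 is expected to give 16500 nM, within a range from 8000 nM to 34000 nM.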

Compound 3, half-maximal inhibitory concentration: 16500 nM
Beside the measured number, compound 3's estimate shows no gap at the digits printed, within the range that was stated.
By their numbers in this assay, from the lowest: compounds 1, 3 and 2 (each within the scatter of the next).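

The exchange of 2-fluorophenyl for 4-chlorophenyl (a 1.1-fold lower number from compound 2 to compound 3 (0.04 log units; within the scatter)) changes both the halogen and its place on the phenyl, yet in this assay it stays within the scatter. Chloro in place of bromo (a 1.0-fold higher number from compound 1 to compound 3 (0.00 log units; within the scatter)) is the first step to change the halogen alone, and it too stays within the scatter, so all three halogen-bearing phenyls at this position on the shared core give numbers within the scatter of one another. Nothing at hand bears on what lies behind this flat result.

As far as these compounds go, all three compounds keep a halogen-bearing phenyl here, so the effect of an amine or a carboxylic acid on that phenyl remains open. Also open, from the compounds shown here alone, is whether a longer chain in place of the phenyl, or a change elsewhere on the shared core, would move the number beyond the scatter.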